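Thiazolylmethyl Amine: Expected Cytotoxicity of Compound 4

A few compounds are considered here, and "the series" means these few. Any claim that something is new, unique, unknown or untested is made for them only; others in the source may bear on it.

Compound 1, `CCCCNc1nc(N)nc2ccn(CC=C(C)C)c12`: > 24000 nM
Compound 2, `CCCCNc1nc(N)nc2ccn(Cc3ccc4ccccc4n3)c12`: > 24000 nM
Compound 3, `COCCCNc1nc(N)nc2ccn(Cc3ccccn3)c12`: > 24000 nM

All three values come from an ADME assay on HEK293 cells (Homo sapiens) for cytotoxicity, read by ATP content, with a stated time of 6 h; on this read-out higher numbers stand for lower toxicity in this test and lower numbers for higher toxicity in this test. Each is a limit of the assay, not a number. Compound 3 stands at the limit of > 24000 nM in this assay, at which 3 of the 3 values shown sit, so it cannot be ranked against the other two; none of the three was toxic within the tested range.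

Compound 4, `Nc1nc(NCc2nccs2)c2c(ccn2Cc2ccccn2)n1`, differs from compound 3 in one place: 1,3-thiazol-2-yl in place of 2-methoxyethyl on a saturated chain carbon bound to a nitrogen on an aromatic ring. Going by the values given here, no measured step covers this change, and no measured step exists in this assay at all, so the expected step is none beyond the scatter: a step that the limit leaves unreadable from compound 3 to compound 4. Compound 4 is therefore expected near 30000 nM, within 15000 nM to 60000 nM, and most likely reported again only as a limit.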

Compound 4, half-maximal cytotoxic concentration: > 24000 nM
Compound 4: no number, only a limit (the forecaster's own chance of this, stated with the estimate: 80%); the middle value does not contradict the limit.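

No step can be read from compound 3 to compound 4 in this assay, because both values are limits of the assay: the limit of > 24000 nM in this assay, at which 4 of the 4 values shown sit.

The compounds shown leave open which of the four is less toxic, and at what concentration any of them becomes toxic.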